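Cytotoxicity notes: oxy-linked versus direct pyridin-3-yl at the aniline ring

The compounds below may be only part of what the source reports. "The series", "measured", "known", "first", "only" and "open" are said of these compounds alone.

Measured compounds and values:
compound 1 `Fc1cccc(F)c1Cc1cnc(Nc2ccc(Oc3cccnc3)c(Cl)c2)o1` gives 16000 nM;
compound 2 `Clc1cccc(Cl)c1Cc1nnc(Nc2ccc(COCc3cccnc3)cc2)o1` gives 81000 nM;
compound 3 `Clc1cccc(Cl)c1Cc1nnc(Nc2ccc(COCc3ccccc3)cc2)o1` gives 84000 nM.

In an ADME assay on MT2 cells (Homo sapiens) for cytotoxicity, read by MTT assay (a higher number here means that more compound is tolerated, a lower number that less compound is tolerated), compound 1 stands lowest of the three numbers, so less of it is tolerated than of compound 2 or compound 3, both of which sit well beyond the scatter above it. Compound 2 and compound 3 share a different core from compound 1 and differ from each other only in the chain end; their gap, a 1.0-fold higher number from compound 2 to compound 3 (0.02 log units; within the scatter), is within the scatter, so nothing separates them.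

The compound now in question, compound 4 `Fc1cccc(F)c1Cc1cnc(Nc2ccc(-c3cccnc3)c(Cl)c2)o1`, keeps the core of compound 1 and changes one group: pyridin-3-yl in place of (pyridin-3-yl)oxy on an aromatic carbon. Among the measured compounds shown here, no measured step covers a linker removal of this kind; the only step on record, from compound 2 to compound 3, swaps a ring on a saturated chain and lies within the scatter, so it gives no direction for this change. With no step beyond the scatter to lean on, the expectation for compound 4 is a step of no change at the digits printed from compound 1 to compound 4 (within the scatter), that is, none beyond the scatter. Compound 4 is estimated at 16000 nM, with a range from 6000 nM to 42000 nM.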

Compound 4, half-maximal cytotoxic concentration: 8900 nM
For compound 4 the middle estimate is 1.8-fold (0.25 log units) above the measured one; the measured number falls inside the stated range.
By their numbers in this assay, from the lowest: compounds 4 and 1 (each within the scatter of the next); then compounds 2 and 3 (each within the scatter of the next).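

In this assay, replacing (pyridin-3-yl)oxy with pyridin-3-yl on the aromatic carbon ortho to a chloro group gives a 1.8-fold lower number from compound 1 to compound 4 (0.25 log units; within the scatter), so compound 1 and compound 4 cannot be told apart and the oxygen link can go without a readable shift in tolerated concentration. Among the compounds shown here, this is the first step read at this position on the core of compound 1, and it gives the series a direct comparison there, which the chain-end step a 1.0-fold higher number from compound 2 to compound 3 (0.02 log units; within the scatter) on a different core could not supply. Both single-place changes now on record lie within the scatter, although they differ in kind and place, and no measurement in hand offers an explanation for the result at this position.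

Going by these compounds, what an amine or a carboxylic acid on this aromatic carbon would do to the number remains open, as does a longer chain in place of the oxygen link. Also open, on these data alone, are the contribution of the chloro group itself and whether removing a link of this kind would read the same on the core of compound 2.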